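Replacing an Ester with a Vinyl Sulfone on a Shared Core

This account rests on a few compounds, and the source may have more. Where it says the series, first, only, none or still open, it means among the compounds named here.

Compound 1 `C=CC(=O)Nc1cc(C(F)(F)F)cc(C(F)(F)F)c1` carries a (vinylcarbonyl)amino group on its aromatic ring, and in an ADME assay for pharmacokinetics, read by LC-MS, in phosphate buffer, with a stated time of 72 h, at pH 7.4, tested at 250 uM (on this read-out lower numbers stand for a shorter-lived compound and higher numbers for a longer-lived compound), compound 1 gives 6.1 h. Compound 2 `C=CC(=O)Oc1cc(C(F)(F)F)cc(C(F)(F)F)c1` differs from it in one place only, with (vinylcarbonyl)oxy in place of (vinylcarbonyl)amino on an aromatic carbon. For compound 2 this assay returns only a limit, < 0.017 h, so its true value is not a number but an edge of what the assay can report; it sits at the limit of < 0.017 h in this assay, at which 1 of the 2 values shown sits. On these data alone, the step of an at least 350-fold lower number from compound 1 to compound 2 (2.55 log units; beyond the scatter) is therefore large, and its full size is unknown.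

Compound 3 `C=CS(=O)(=O)c1cc(C(F)(F)F)cc(C(F)(F)F)c1` is not yet measured. Its change from compound 2 is vinylsulfonyl in place of (vinylcarbonyl)oxy on an aromatic carbon. Among the compounds with values here, no measured step covers a vinylsulfonyl group, and the one measured step concerns a different exchange, so it gives no direct guide. Since compound 2 stands at the limit, any reported number for compound 3 can only be higher or again a limit. Compound 3 is expected to give about 20 h, within 1 h to 200 h, which would mean an estimated step of an at least 1100-fold higher number from compound 2 to compound 3 (3.07 log units; beyond the scatter).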

Compound 3, half-life: < 0.017 h
Compound 3: a limit, no number; the forecaster's own chance of this, stated with the estimate: 25%; middle value at least 1100-fold (3.07 log units) from the limit.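

Set against the (vinylcarbonyl)amino group of compound 1, the vinylsulfonyl group gives an at least 350-fold lower number from compound 1 to compound 3 (2.55 log units; beyond the scatter), so a second, different group at this aromatic carbon also fails to keep the half-life seen with compound 1. In this assay, compound 3 gives < 0.017 h, which is a limit of the assay and not a number. Compound 2 and compound 3 therefore stand at the same edge of what can be reported, and the step between them cannot be read, so the two groups cannot be ranked against each other: the limit of < 0.017 h in this assay, at which 2 of the 3 values shown sit.

The true half-lives of compound 2 and compound 3 stay hidden behind that limit, so how far apart they lie remains open, and of the three groups shown on the shared core, only the (vinylcarbonyl)amino group gives a readable number. On these data alone, whether that number depends on the nitrogen link or on the vinylcarbonyl part also remains open, and a vinylsulfonylamino group or a chloroacetylamino group in the same place would be needed to separate the two.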